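A few compounds are considered here, and "the series" means these few. Any claim that something is new, unique, unknown or untested is made for them only; others in the source may bear on it.

Compound 1 `O=S(=O)(NCCCNCc1cccc2ccccc12)c1cc(C(F)(F)F)cc(C(F)(F)F)c1` gives 2400 nM in a functional assay on HPAC cells (Homo sapiens) for inhibition, read by MTT assay, with a stated time of 72 h; on this read-out lower numbers stand for stronger inhibition of growth and higher numbers for weaker inhibition of growth.
Compound 2 `O=S(=O)(NCCNCc1ccc(-c2ccccc2)cc1)c1cc(C(F)(F)F)cc(C(F)(F)F)c1` gives 2800 nM in this assay.
Compound 3 `COc1cccc(CNCCCNS(=O)(=O)c2cc(C(F)(F)F)cc(C(F)(F)F)c2)c1` gives 2400 nM in this assay.

All three share one core and differ only in the aromatic group carried on the chain. Compound 3 stands level with compound 1, and compound 2 sits within the scatter of both, so the three numbers cannot be told apart. Among the measured compounds shown here, the one step that bears on the next change is no change at the digits printed from compound 1 to compound 3 (within the scatter), which shows that exchanging one aromatic group for another left the number where it was. Compound 4 `O=S(=O)(NCCCNCc1ccc(Cl)c(Cl)c1)c1cc(C(F)(F)F)cc(C(F)(F)F)c1` has not yet been measured; it differs from compound 3 by 3,4-dichlorophenyl in place of 3-methoxyphenyl on a saturated chain carbon bound to an amine nitrogen. For the measured compounds named here, since the only comparable step showed no change, compound 4 is expected to show a 1.2-fold lower number from compound 3 to compound 4 (0.08 log units; within the scatter), nothing beyond the scatter. Compound 4 is estimated at 2000 nM, with a range from 800 nM to 5000 nM.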

Compound 4, concentration for 50% growth inhibition: 2500 nM
Estimate against measurement, compound 4: 1.3-fold (0.10 log units) below; the measured number falls inside the stated range.
By their numbers in this assay, from the lowest: compounds 1, 3, 4 and 2 (each within the scatter of the next).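

In this assay, putting 3,4-dichlorophenyl in place of 3-methoxyphenyl on a saturated chain carbon bound to an amine nitrogen gives a 1.0-fold higher number from compound 3 to compound 4 (0.02 log units; within the scatter), and putting it in place of naphthalen-1-yl gives a 1.0-fold higher number from compound 1 to compound 4 (0.02 log units; within the scatter). So a third aromatic group, this one with chlorine atoms and no hydrogen-bond acceptor, also cannot be told apart from the others here. No evidence is available to explain these results. Still open, going by these compounds, is whether a pyridin-3-yl group, a cyclohexyl group or a carboxylic acid at this position would move the number beyond the scatter.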